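A few compounds are considered here, and "the series" means these few. Any claim that something is new, unique, unknown or untested is made for them only; others in the source may bear on it.

Three related compounds have been measured so far in an ADME assay on L6 cells (Rattus norvegicus) for inhibition, read by resazurin assay, with a stated time of 72 h; on this read-out lower numbers stand for stronger inhibition and higher numbers for weaker inhibition. Compound 1 `C[S+]([O-])C[C@H]1O[C@@H](n2cnc3c(N)nc(Cl)nc32)[C@H](O)[C@@H]1O` gives 259000 nM and has the highest number of the three. Compound 2 `CC(=O)O[C@@H]1[C@H](OC(C)=O)[C@@H](CS(C)(=O)=O)O[C@H]1n1cnc2c(N)nc(Cl)nc21` gives 114000 nM and stands in the middle, closer to compound 1 than to compound 3. Compound 3 `CS(=O)(=O)C[C@H]1O[C@@H](n2cnc3c(N)nc(F)nc32)[C@H](O)[C@@H]1O` gives 5000 nM and has the lowest number.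

The open question is compound 4 `CC(=O)O[C@@H]1[C@H](OC(C)=O)[C@@H](CI)O[C@H]1n1cnc2c(N)nc(Cl)nc21`, which differs from compound 2 in one group: iodo in place of methylsulfonyl on a saturated chain carbon bound to a saturated ring carbon and so has iodo in place of methylsulfonyl on a saturated chain carbon bound to a saturated ring carbon.

For the measured compounds named here, no two measured compounds differ in one place only, so nothing here tests this exchange directly, and any forecast is loose. A moderate step toward a lower number in this assay seems the likeliest outcome, beyond the scatter but with no certainty. Compound 2 at 114000 nM lies near the high end of the measured span, while compound 3 at 5000 nM shows that much lower numbers occur among these compounds. The estimated step of a 3.8-fold lower number from compound 2 to compound 4 (0.58 log units; beyond the scatter) is only an expectation with a wide margin. Compound 4 is expected to give about 30000 nM in this read-out. The expected range for it runs from 6000 nM to 130000 nM in the same units.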

Compound 4, half-maximal inhibitory concentration: 86000 nM
For compound 4 the middle estimate is 2.9-fold (0.46 log units) below the measured one; low and high end bracket the measured number.
By their numbers in this assay, from the lowest: compound 3; then compounds 4 and 2 (each within the scatter of the next); then compound 1.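

For the compounds shown here, replacing methylsulfonyl with iodo on a saturated chain carbon bound to a saturated ring carbon is the one exchange here that can be read directly, and in this assay it gives a 1.3-fold lower number from compound 2 to compound 4 (0.12 log units; within the scatter) and so stays within the usual scatter of repeated measurements. The group that leaves has 4 heavy atoms and 2 hydrogen-bond acceptors, while the iodo that enters has 1 heavy atom and no acceptors, so at this place, in the core of compound 2, a large change in these counts comes with no measurable shift in the read-out. No measurement of any property is available to explain this result.

This single pair cannot show whether other groups at this place, such as an amine, a carboxylic acid or a longer chain, would also leave the number unchanged. Going by these compounds, compound 3 differs from compound 2 in more than one place, so it remains open whether the same exchange would also make no measurable difference in the core of compound 3.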